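Benzyl esters in the hydroxystyryl dienoate series

The compounds below may be only part of what the source reports. "The series", "measured", "known", "first", "only" and "open" are said of these compounds alone.

Measured so far:
compound 1 `C=C[C@@](C)(/C=C/c1ccc(O)cc1)CC/C=C/C(=O)OCC` — > 43400 nM
compound 2 `C=C[C@@](C)(/C=C/c1ccc(O)cc1)CC/C=C/C(=O)OCc1ccccc1` — > 43400 nM
compound 3 `C=C[C@@](C)(/C=C/c1ccc(O)cc1)CC/C=C(C)/C=C/C(=O)OCC` — 815 nM

In a functional assay on NALM-6 cells (Homo sapiens) for cytotoxicity, with a stated time of 72 h (a lower number here means that less compound is needed, a higher number that more compound is needed for the effect), compound 1 gives > 43400 nM, which is a limit and not a number. Compound 2 likewise gives only a limit, > 43400 nM. For the measured compounds named here, compound 3 gives 815 nM, the sole number in the set. From compound 1 to compound 2 the change is phenyl in place of methyl on a saturated chain carbon bound to an oxygen next to a carbonyl group; its step that the two limits leave unreadable from compound 1 to compound 2 cannot be read because both values sit at the limit of > 43400 nM in this assay, at which 2 of the 3 values shown sit. The difference between the core of compound 1 and the core of compound 3 is not broken down here.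

Compound 4 `C=C[C@@](C)(/C=C/c1ccc(O)cc1)CC/C=C(C)/C=C/C(=O)OCc1ccccc1` carries the same change on compound 3: phenyl in place of methyl on a saturated chain carbon bound to an oxygen next to a carbonyl group. The expected step is a 1.2-fold higher number from compound 3 to compound 4 (0.09 log units; within the scatter). That estimate rests on compound 3 at 815 nM alone, the earlier step being unreadable. Compound 4 is expected to give about 1000 nM in this assay, between 250 nM and 4500 nM.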

Compound 4, half-maximal effective concentration: 36000 nM
Compound 4: the middle estimate sits 36-fold (1.56 log units) below what was measured; measured number above the stated range.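

Carried onto the second core, ethyl to benzyl gives a large step in this assay: a 44-fold higher number from compound 3 to compound 4 (1.65 log units; beyond the scatter). On the core of compound 1 the same change yields no readable step, since compound 1 and compound 2 both rest on a limit and not a number: the limit of > 43400 nM in this assay, at which 2 of the 4 values shown sit. The series therefore holds one readable step on one core, which shows that the change can matter greatly there but not that it acts alike on the other core.

Open, on these data alone, is how a longer chain such as butyl, or a carboxylic acid in place of the ester, would read on either core. Also open, as far as these compounds go, is whether a benzyl ester on any further core repeats this step.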